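The compounds below may be only part of what the source reports. "The series", "measured", "known", "first", "only" and "open" are said of these compounds alone.

Notes on the series, read in a physicochemical assay for solubility, read by chemiluminescence, measured as kinetic solubility; a higher number here means a more soluble compound, a lower number a less soluble compound. Within the data shown here, compound 3 `CN[C@H](C)C(=O)NCc1cccc(Cn2nc(NS(=O)(=O)c3ccc(Cl)s3)c3c(OC)cccc32)c1` gives 191 ug/mL, the only true number among the three measured compounds. Compound 1 `COc1cccc2c1c(NS(=O)(=O)c1ccc(Cl)s1)nn2Cc1cccc(CNC(=O)C2COC2)c1` reads >= 173 ug/mL, which is a limit of the assay and not a number. Compound 2 `COc1cccc2c1c(NS(=O)(=O)c1ccc(Cl)s1)nn2Cc1cccc(CNC(=O)C2CCOCC2)c1` reads >= 193 ug/mL, which is also a limit.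

Compound 4 `COc1cccc2c1c(NS(=O)(=O)c1ccc(Cl)s1)nn2Cc1cccc(CNC(=O)[C@@H]2CCCCN2)c1` keeps the shared core and changes only the group on a carbonyl carbon whose other neighbours are an amide-type nitrogen: piperidin-2-yl in place of 1-(methylamino)ethyl on a carbonyl carbon. The open-chain 1-(methylamino)ethyl gives way to the ring of piperidin-2-yl.

Three measured steps fall at this same carbonyl carbon: a step that the two limits leave unreadable from compound 1 to compound 2; a step that the limit leaves unreadable from compound 1 to compound 3; a number no higher from compound 2 to compound 3 (the limit leaves the size open). None of them gives a readable size, so the series offers no measured size for a change at this place, and none for this exact replacement. The expectation in this assay therefore rests on compound 3 at 191 ug/mL, with no direction favoured on the measured steps. The expected step, no larger than the usual scatter, is a 1.1-fold lower number from compound 3 to compound 4 (0.03 log units; within the scatter). For compound 4 the estimated value is 180 ug/mL, with an expected range of 110 ug/mL to 230 ug/mL. A report as a limit rather than a number would be no surprise in this set.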

Compound 4, solubility: >= 220 ug/mL
Compound 4: no number, only a limit (the forecaster's own chance of this, stated with the estimate: 45%); middle value at least 1.2-fold (0.08 log units) from the limit.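

In this assay compound 4 reads >= 220 ug/mL, which is a limit of the assay and not a number. Among these compounds, with the ring of piperidin-2-yl in place of the open-chain 1-(methylamino)ethyl on a carbonyl carbon, this position now gives its first step with a readable floor, an at least 1.1-fold higher number from compound 3 to compound 4 (0.06 log units; that floor lies within the scatter), and that direction is the first the series offers for a change here, although the floor itself stays within the scatter. As far as these compounds go, the size of the step remains open because compound 4 stands at a limit, and the steps to compound 4 from compound 1 and from compound 2 cannot be read, so the ring shows no sign of a lower number but cannot be ranked against the oxetan-3-yl or oxan-4-yl groups: the limit of >= 220 ug/mL in this assay, at which 1 of the 4 values shown sits.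

Among the compounds shown here, how far compound 1, compound 2 and compound 4 actually lie beyond their limits stays unknown, so compound 3 remains the only true number and no order can be drawn among the others. Also open, from the compounds shown here alone, is how a pyrrolidin-2-yl ring, the opposite stereocentre of piperidin-2-yl, or a carboxylic acid on a longer chain at this carbonyl carbon would read in this assay.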